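Pyridin-3-yl replacing 4-(trifluoromethyl)phenyl at the assay limit

The source may report more compounds than this note shows. Statements on the series, on what has been measured and on what is new or still open speak of the compounds shown alone.

In an ADME assay on HepG2 2.2.15 cells (Homo sapiens) for cytotoxicity (on this read-out lower numbers stand for higher toxicity in this test and higher numbers for lower toxicity in this test), compound 1 `O=C(OCCc1c(-c2ccccc2Cl)c2cc(Cl)ccc2[nH]c1=O)c1cccs1` gives > 1700000 nM as a limit, not a number. Compound 2 `O=C(/C=C/c1ccc(C(F)(F)F)cc1)OCCc1c(-c2ccccc2Cl)c2cc(Cl)ccc2[nH]c1=O` stands at > 1400000 nM which is likewise only a limit. Compound 3 `O=C(/C=C/c1cccnc1)OCCc1c(-c2ccccc2Cl)c2cc(Cl)ccc2[nH]c1=O` differs from it by pyridin-3-yl in place of 4-(trifluoromethyl)phenyl on a double-bonded chain carbon bound to a double-bonded chain carbon with pyridin-3-yl in place of 4-(trifluoromethyl)phenyl. Among the measured compounds shown here, the only measured step that bears on this is a step that the two limits leave unreadable from compound 1 to compound 2 and it has no readable size, so no change beyond the scatter is expected in this assay and no direction can be given. The expected step is a step that the limit leaves unreadable from compound 2 to compound 3 and lies within that scatter. Compound 3 is estimated at 1600000 nM with an expected range of 800000 nM to 3000000 nM. Compound 3 may again give only a limit.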

Compound 3, half-maximal cytotoxic concentration: 39000 nM
For compound 3 the middle estimate is 41-fold (1.61 log units) above the measured one; the measured number lies below the stated range.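

In this assay, pyridin-3-yl in place of 4-(trifluoromethyl)phenyl on a double-bonded chain carbon bound to a double-bonded chain carbon gives an at least 35-fold lower number from compound 2 to compound 3 (1.55 log units; beyond the scatter), and 2-(pyridin-3-yl)ethenyl in place of thiophen-2-yl on a carbonyl carbon gives an at least 43-fold lower number from compound 1 to compound 3 (1.63 log units; beyond the scatter). Unlike the earlier step, which cannot be read, these show that the group at this position can move the read-out toward higher toxicity in this test. The first step has no upper size because compound 2 gives only a limit: the limit of > 1400000 nM in this assay, at which 1 of the 3 values shown sits.

The compounds shown do not separate the entering ring nitrogen from the loss of trifluoromethyl. Going by these compounds, how an unsubstituted phenyl or a pyridin-4-yl would read at this position stays open.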